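A few compounds are considered here, and "the series" means these few. Any claim that something is new, unique, unknown or untested is made for them only; others in the source may bear on it.

In a functional assay on HCT-116 cells (Homo sapiens) for inhibition, read by MTT assay, with a stated time of 2 days (a higher number here means a weaker inhibitor of growth, a lower number a stronger inhibitor of growth), the measured compounds stand as follows

Compound 1 `Nc1ccccc1NC(=O)CCCNCC(=O)Nc1ccc(Cl)cc1` gives 5500 nM
Compound 2 `Nc1ccccc1NC(=O)CCCNCC(=O)Nc1cc(Cl)ccc1Cl` gives 31000 nM

Going by the values given here, compound 2 holds the higher of the two numbers, and its only neighbour is compound 1 (5500 nM). Compound 3 `Nc1ccccc1NC(=O)CCCNCC(=O)Nc1ccccc1Cl` comes from compound 2 by a single change (hydrogen in place of chloro on an aromatic carbon): hydrogen in place of chloro on an aromatic carbon, which turns 2,5-dichlorophenyl into 2-chlorophenyl. Among the compounds with values here, only one measured step bears on this (a 5.6-fold higher number from compound 1 to compound 2 (0.75 log units; beyond the scatter)). It is modest but beyond the scatter. Within the data shown here, it bears only indirectly, since it does not show the removal of this chloro on its own, and no measured pair does. A modest move toward the lower number of compound 1 (5500 nM) is therefore expected, though the direction is not secure. The expected change is an estimate (a 2.6-fold lower number from compound 2 to compound 3 (0.41 log units; beyond the scatter)). For compound 3 the estimated value is 12000 nM (expected range 4500 nM to 32000 nM).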

Compound 3, concentration for 50% growth inhibition: 21800 nM
Compound 3: the middle estimate sits 1.8-fold (0.26 log units) below what was measured, and the stated range covers the measured number.
By their numbers in this assay, from the lowest: compound 1; then compounds 3 and 2 (each within the scatter of the next).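

In this assay, the change from 2,5-dichlorophenyl to 2-chlorophenyl gives a 1.4-fold lower number from compound 2 to compound 3 (0.15 log units; within the scatter) and so leaves no difference that can be told from the scatter; the chloro at this place, para to the other chloro group, therefore carries little weight on its own in this pair. The step that does stand out concerns where a single chloro sits, since 2-chlorophenyl in place of 4-chlorophenyl gives a 4.0-fold higher number from compound 1 to compound 3 (0.60 log units; beyond the scatter) and both compounds carrying the 2-chlorophenyl pattern, compound 2 and compound 3, now stand apart from compound 1 by more than the scatter. Nothing available explains this difference between the two chlorophenyl groups.

The compounds shown leave open how a plain phenyl group, or a fluoro or methoxy group in place of the chloro of compound 1, would compare with these three. They also leave open whether the same order of the chlorophenyl groups would hold with a longer chain in the shared core, or in other cell lines.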